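The source may hold more compounds than are shown below. What is called first, only, known or untested is meant among the compounds shown, and "the series" means these compounds.

In an ADME assay on microsomes from liver (Homo sapiens) for metabolic stability, read by LC-MS, using NADPH, with a stated time of 10 min, tested at 10 uM (a lower number here means that the compound disappears faster, a higher number that the compound lasts longer), compound 3 `Nc1ncnc2c1c(Oc1cccc(Cl)c1)nn2[C@H]1C[C@H](F)C1` gives 0.153 h, the lowest of the measured numbers. Compound 2 `Nc1ncnc2c1c(Oc1cc(C(F)(F)F)ccn1)nn2[C@H]1C[C@H](F)C1`, which shares its 3-fluorocyclobutyl but differs on the oxygen, gives 2.03 h, a gap beyond the scatter. Compound 1 `Nc1ncnc2c1c(Oc1cc(C(F)(F)F)ccn1)nn2C1CC1` reports only a limit, > 2.41 h.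

The next change gives compound 4 `Nc1ncnc2c1c(Oc1cc(O)ccn1)nn2[C@H]1C[C@H](F)C1`: 4-hydroxypyridin-2-yl in place of 3-chlorophenyl on an oxygen on an aromatic ring, (4-hydroxypyridin-2-yl in place of 3-chlorophenyl on an oxygen on an aromatic ring).

Among the compounds with values here, the one measured step, 3-fluorocyclobutyl in place of cyclopropyl on an aromatic nitrogen, is an at least 1.1-fold lower number from compound 1 to compound 2 (0.07 log units; that floor lies within the scatter). It rests on (the limit of > 2.41 h in this assay, at which 1 of the 3 values shown sits), its floor lies within the scatter, and it sits at a different place, so it says little here. Within the data shown here, no measured compound carries 4-hydroxypyridin-2-yl. A rise is expected because compound 2 at 2.03 h shows how far a change on that oxygen can move the number, though the full gap is not assumed. The expected step is a 7.8-fold higher number from compound 3 to compound 4 (0.89 log units; beyond the scatter). For compound 4 the estimated half-life is 1.2 h, with an expected range of 0.4 h to 3 h.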

Compound 4, half-life: 1.03 h
Beside the measured number, compound 4's estimate is 1.2-fold (0.07 log units) above it; measured number inside the range.
By their numbers in this assay, from the lowest: compound 3; then compounds 4 and 2 (each within the scatter of the next). At a limit, above all of these: compound 1.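

In this assay, with the 3-fluorocyclobutyl held constant, the change on the oxygen gives a 6.7-fold higher number from compound 3 to compound 4 (0.83 log units; beyond the scatter): 4-hydroxypyridin-2-yl in place of 3-chlorophenyl is a step beyond the scatter at this position. Hydroxy in place of trifluoromethyl on an aromatic carbon gives a 2.0-fold lower number from compound 2 to compound 4 (0.29 log units; within the scatter), which lies within the scatter, so trifluoromethyl and hydroxy are not separated on this ring and the half-life does not depend on trifluoromethyl alone. Nothing shown here gives a measured reason for either step.

The compounds shown leave open whether the ring hetero atom or the hydroxy carries the step away from 3-chlorophenyl. As far as these compounds go, how an amine or a carboxylic acid on that aromatic carbon would read also remains open.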